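Acyl variation on the ring amide nitrogen

The source may report more compounds than this note shows. Statements on the series, on what has been measured and on what is new or still open speak of the compounds shown alone.

Compound 1 `CCCCNc1nc(N)nc2c1CN(C(C)=O)CC2` gives 0.5 uM in an assay on HEK293 cells for agonist activity at Toll-like receptor 8 (Homo sapiens), read by a luciferase reporter, with a stated time of 6 h; a higher number here means that more compound is needed for the effect, a lower number that less compound is needed. Going by the values given here, compound 2 `CCCCNc1nc(N)nc2c1CN(C(=O)C(C)C)CC2` gives 1.6 uM in this assay, the highest of the two numbers so far; the step of a 3.2-fold higher number from compound 1 to compound 2 (0.51 log units; beyond the scatter) lies beyond the scatter. Compound 3 `CCCCNc1nc(N)nc2c1CN(C(=O)c1cnc(C)cn1)CC2` carries 5-methylpyrazin-2-yl in place of isopropyl on a carbonyl carbon. Among the compounds with values here, no measured step exchanges an alkyl group for an aromatic ring on the carbonyl carbon; the only step that bears on it, a 3.2-fold higher number from compound 1 to compound 2 (0.51 log units; beyond the scatter), shows a modest rise. A further modest rise is therefore expected for compound 3, estimated at 2.5 uM with a range of 0.6 uM to 10 uM, an expected step of a 1.6-fold higher number from compound 2 to compound 3 (0.19 log units; within the scatter).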

Compound 3, minimum effective concentration: 6.8 uM
Compound 3: middle estimate off by 2.7-fold (0.43 log units), on the low side; the measured number falls inside the stated range.
By their numbers in this assay, from the lowest: compound 1; then compound 2; then compound 3.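

In this assay the carbonyl carbon still tolerates an aromatic ring, with a 4.3-fold higher number from compound 2 to compound 3 (0.63 log units; beyond the scatter) as a second rise and a 14-fold higher number from compound 1 to compound 3 (1.13 log units; beyond the scatter) as the large overall span. The numbers now climb in the order methyl, isopropyl, 5-methylpyrazin-2-yl, and no compound shown goes against that order. Nothing on hand explains this climb. Still open, as far as these compounds go, is whether the aromatic ring or the size of the group carries the rise. A plain phenyl ring or a straight butyl chain on the carbonyl carbon would separate the two.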